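A few compounds are considered here, and "the series" means these few. Any claim that something is new, unique, unknown or untested is made for them only; others in the source may bear on it.

Of the compounds shown here, three built on one shared core have been measured in an assay on CHO cells for displacement of a labelled ligand from Substance-P receptor (Homo sapiens); on this read-out higher numbers stand for weaker inhibition and lower numbers for stronger inhibition. Compound 1 `COc1cc(C2=CC(=O)N3C[C@H](O[C@H](C)c4cc(C(F)(F)F)cc(C(F)(F)F)c4)[C@@H](c4ccc(F)cc4)C3C2)ccn1` gives 1.1 nM, compound 2 `C[C@@H](O[C@H]1CN2C(=O)C=C(c3cc[nH]c(=O)c3)CC2[C@@H]1c1ccc(F)cc1)c1cc(C(F)(F)F)cc(C(F)(F)F)c1` gives 0.27 nM, and compound 3 `C[C@@H](O[C@H]1CN2C(=O)C=C(c3cnn(Cc4ccccc4)c3)CC2[C@@H]1c1ccc(F)cc1)c1cc(C(F)(F)F)cc(C(F)(F)F)c1` gives 1.9 nM. Compound 3 therefore carries the highest number of the three: the step of a 7.0-fold higher number from compound 2 to compound 3 (0.85 log units; beyond the scatter) lies beyond the scatter, whereas a 1.7-fold higher number from compound 1 to compound 3 (0.24 log units; within the scatter) does not. Compound 4 `C[C@@H](O[C@H]1CN2C(=O)C=C(C3CCOCC3)CC2[C@@H]1c1ccc(F)cc1)c1cc(C(F)(F)F)cc(C(F)(F)F)c1` differs from compound 3 in one place: oxan-4-yl in place of 1-benzyl-1H-pyrazol-4-yl on a double-bonded ring carbon. The measured steps that bear on this change each swap the group on the same double-bonded ring carbon, namely a 4.1-fold lower number from compound 1 to compound 2 (0.61 log units; beyond the scatter), a 1.7-fold higher number from compound 1 to compound 3 (0.24 log units; within the scatter) and a 7.0-fold higher number from compound 2 to compound 3 (0.85 log units; beyond the scatter), all modest at most. None of them brings in a six-membered non-aromatic ring with one hetero atom, so they set only the scale. A step of a 2.6-fold higher number from compound 3 to compound 4 (0.42 log units; beyond the scatter) is expected. Compound 4 is estimated at 5 nM, within a range of 1 nM to 25 nM.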

Compound 4, half-maximal inhibitory concentration: 0.09 nM
Compound 4: the middle estimate sits 56-fold (1.74 log units) above what was measured; measured number outside the range, below it.
By their numbers in this assay, from the lowest: compound 4; then compound 2; then compounds 1 and 3 (each within the scatter of the next).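

Oxan-4-yl, a six-membered non-aromatic ring, on this double-bonded ring carbon gives the lowest number of the four compounds in this assay: the step from the benzylpyrazole is large (a 21-fold lower number from compound 3 to compound 4 (1.32 log units; beyond the scatter)), the step from the methoxypyridine is also large (a 12-fold lower number from compound 1 to compound 4 (1.09 log units; beyond the scatter)), and the step from the pyridone-bearing compound is modest (a 3.0-fold lower number from compound 2 to compound 4 (0.48 log units; beyond the scatter)). An aromatic ring at this carbon is therefore not needed for a low number here. The data offer no measured explanation for this gain. On these data alone, whether a piperidin-4-yl ring or an open methoxyethyl chain at this carbon would keep such a number remains open.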